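The compounds below may be only part of what the source reports. "The series", "measured", "known", "first", "only" and "open" are said of these compounds alone.

Measured set, in a functional assay on A-431 cells (Homo sapiens) for antiproliferative activity, read by MTT assay, with a stated time of 72 h; on this read-out higher numbers stand for weaker inhibition and lower numbers for stronger inhibition:
compound 1 `COc1cc2ncnc(Nc3ccc(F)cc3)c2cc1OCCCCC(=O)Nc1ccc(S(N)(=O)=O)cc1` gives 18600 nM
compound 2 `NS(=O)(=O)c1ccc(NC(=S)Nc2ccc3ncnc(Nc4cccc(C(F)(F)F)c4)c3c2)cc1` gives 21700 nM
compound 3 `NS(=O)(=O)c1ccc(NC(=S)Nc2ccc3ncnc(Nc4ccc(Cl)c(C(F)(F)F)c4)c3c2)cc1` gives 18200 nM

Compound 3 has the lowest number of the three, but its gap to compound 1 and its gap to compound 2 are both within the scatter, so the three stand together and no order can be read among them. For the measured compounds named here, the only single-point step recorded, a 1.2-fold lower number from compound 2 to compound 3 (0.08 log units; within the scatter), is also within the scatter.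

Compound 4 `NS(=O)(=O)c1ccc(NC(=S)Nc2ccc3ncnc(Nc4cccc(Cl)c4F)c3c2)cc1` differs from compound 3 by 3-chloro-2-fluorophenyl in place of 4-chloro-3-(trifluoromethyl)phenyl on a nitrogen on an aromatic ring. Going by the values given here, no recorded step changes this aryl group in the same way; the step from compound 2 to compound 3, which touches the same group with a smaller change, gives no movement beyond the scatter, and compound 1 with an unrelated aryl sits at the same level. On this basis the expectation for compound 4 is a step of a 1.2-fold lower number from compound 3 to compound 4 (0.08 log units; within the scatter), which is no change beyond the scatter, and compound 4 is estimated at 15000 nM, with a range from 4500 nM to 50000 nM.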

Compound 4, half-maximal inhibitory concentration: 13100 nM
The estimate for compound 4 lay 1.1-fold (0.06 log units) above the measured number; the measured number falls inside the stated range.
By their numbers in this assay, from the lowest: compounds 4, 3, 1 and 2 (each within the scatter of the next).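

In this assay, the two new steps at the aryl group on the nitrogen are a 1.4-fold lower number from compound 3 to compound 4 (0.14 log units; within the scatter) and a 1.7-fold lower number from compound 2 to compound 4 (0.22 log units; within the scatter). The earlier step only added chloro to an aryl group that kept its trifluoromethyl, whereas these steps show that the trifluoromethyl group itself can be exchanged for a chloro and fluoro pattern with no movement beyond the scatter. No measurement available here accounts for this flat result.

Going by these compounds, it remains open whether any group at this position can move the number beyond the scatter, for example an aryl group carrying an amine or a carboxylic acid. With all steps at this position within the scatter, the compounds shown define no ordering among these aryl groups.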